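Double bond configuration in the fluoro compounds

This account rests on a few compounds, and the source may have more. Where it says the series, first, only, none or still open, it means among the compounds named here.

In a functional assay on MCF7 cells (Homo sapiens) for cytotoxicity, read by MTT assay, with a stated time of 48 h (a higher number here means a weaker inhibitor, a lower number a stronger inhibitor), the compounds stand as follows.
- compound 1 `C/C(=N\NC(=S)Nc1ccc(Cl)cc1)c1ccccn1` gives 8.49 nM 
- compound 2 `C/C(=N/NC(=S)Nc1ccc(Cl)cc1)c1ccccn1` gives 8.49 nM 
- compound 3 `C/C(=N\NC(=S)Nc1ccc(F)cc1)c1ccccn1` gives 1.2 nM 
- compound 4 `C/C(=N/NC(=S)Nc1ccc(F)cc1)c1ccccn1` has no value yet

Compound 3 holds the lowest of the three numbers, and its gap to compound 1 and to compound 2 lies beyond the scatter. Fluoro in place of chloro on an aromatic carbon is a 7.1-fold lower number from compound 1 to compound 3 (0.85 log units; beyond the scatter) and this is the step that sets compound 3 apart.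

The next comparison is the two compounds have the same atoms and bonds and differ only in configuration as drawn: 1 of 1 stereo elements differ; a double bond is drawn E in compound 3 and Z in compound 4 with nothing leaving and nothing entering. Among the compounds with values here, only one measured step is of this kind, in the chloro pair, where the fact that compounds 1 and 2 differ only in the configuration as drawn is all that separates the two structures. That step is no change at the digits printed from compound 1 to compound 2 (within the scatter) and the step with fluoro in place of chloro says nothing about configuration. Within the data shown here, no step beyond the scatter is expected in this assay because no change at the digits printed from compound 1 to compound 2 (within the scatter) is the sole guide, and a single pair is thin support. The expected size of the change is no change at the digits printed from compound 3 to compound 4 (within the scatter) and its direction is left open. For compound 4 the estimated value is 1.2 nM with an expected range of 0.6 nM to 2.6 nM (an estimate until measured).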

Compound 4, half-maximal inhibitory concentration: 1.2 nM
For compound 4 middle estimate and measured number coincide at the digits printed; measured number inside the range.
By their numbers in this assay, from the lowest: compounds 3 and 4 (each within the scatter of the next); then compounds 1 and 2 (each within the scatter of the next).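

In this assay, the configuration of the double bond now has a second pair, on the fluoro side: no change at the digits printed from compound 3 to compound 4 (within the scatter), so the absence of a step seen in the chloro pair is no longer a single observation: the fact that compounds 3 and 4 differ only in the configuration as drawn. The halogen change can also now be read on the compounds drawn Z, where a 7.1-fold lower number from compound 2 to compound 4 (0.85 log units; beyond the scatter), so it no longer rests on the compounds drawn E alone: the same change on two cores in this assay, a 7.1-fold lower number (0.85 log units; beyond the scatter) from compound 1 to compound 3 and a 7.1-fold lower number (0.85 log units; beyond the scatter) from compound 2 to compound 4, 1.0-fold (0.00 log units) apart, within the scatter of two such steps. Across compounds 1 to 4, the number follows the halogen on the aromatic ring and not the drawn configuration, and none of the four goes against this.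

With only fluoro and chloro shown at this position, it remains open whether bromo, methoxy, trifluoromethyl or a nitrile would extend the same trend or break it, and whether the unsubstituted phenyl ring would sit with either halogen. The matching digits within each configuration pair also leave open whether the forms drawn E and Z stay distinct over the time of the assay, and the compounds shown cannot settle that.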